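The source may hold more compounds than are shown below. What is called first, only, known or untested is meant among the compounds shown, and "the series" means these compounds.

In a functional assay on SF-295 cells (Homo sapiens) for inhibition, read by sulforhodamine B assay, with a stated time of 48 h (on this read-out lower numbers stand for stronger inhibition of growth and higher numbers for weaker inhibition of growth), compound 2 `COc1cc2cc(Oc3ccc(NC(=O)Nc4ccc(Cl)c(C(F)(F)F)c4)cc3)c(C)nc2cc1OC` gives 899 nM. Its only comparator, compound 1 `COc1cc2cc(Oc3ccc(NC(=O)Nc4cccc(C(F)(F)F)c4)cc3)c(C)nc2cc1OC`, gives 1130 nM in this assay; the difference, a 1.3-fold lower number from compound 1 to compound 2 (0.10 log units; within the scatter), means the two cannot be told apart, so compound 2 stands alongside compound 1 rather than ahead of it. Compound 3 `COc1cc2cc(Oc3ccc(NC(=O)Nc4ccc(Cl)c(Cl)c4)cc3)c(C)nc2cc1OC` differs from compound 2 by chloro in place of trifluoromethyl on an aromatic carbon. Among the compounds with values here, only one measured step bears on this ring: the change from compound 1 to compound 2 put chloro in place of hydrogen on an aromatic carbon and left the number essentially unchanged. Within the data shown here, no measured step exchanges a trifluoromethyl for a chloro, so the available guide is that a single small change on this ring has so far stayed within the scatter. The expected step is therefore a 1.2-fold higher number from compound 2 to compound 3 (0.09 log units; within the scatter), no more than the scatter. Compound 3 is estimated at 1100 nM, with a range expected from 400 nM to 3000 nM.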

Compound 3, concentration for 50% growth inhibition: 1960 nM
Compound 3: middle estimate off by 1.8-fold (0.25 log units), on the low side, and the stated range covers the measured number.
By their numbers in this assay, from the lowest: compounds 2, 1 and 3 (each within the scatter of the next, the first and the last beyond it).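

In this assay, within the data shown here, this position, on an aromatic carbon ortho to a chloro group, gives the first single change that passes the usual scatter: chloro replaces trifluoromethyl, with a 2.2-fold higher number from compound 2 to compound 3 (0.34 log units; beyond the scatter), a modest step. The separation is limited, since the comparison with the compound lacking the ring chloro, a 1.7-fold higher number from compound 1 to compound 3 (0.24 log units; within the scatter), stays within the scatter, so compound 3 cannot be told apart from compound 1 and differs clearly only from compound 2. Nothing measured here explains why the swap matters.

Among these compounds, what remains open is whether the trend depends on the chloro group already on the ring, as only one pair makes this exact swap. As far as these compounds go, how a methoxy group or an amine at this position would read in this assay also stays unknown.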